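A few compounds are considered here, and "the series" means these few. Any claim that something is new, unique, unknown or untested is made for them only; others in the source may bear on it.

Going by the values given here, in a physicochemical assay for solubility, with a stated time of 3 days, at pH 7 (a lower number here means a less soluble compound, a higher number a more soluble compound), compound 1 `NC(=O)c1ccc2[nH]c(-c3ccc(OCCC4CCCCN4Cc4ccccc4)cc3)nc2c1` gives 155000 nM and compound 2 `NC(=O)c1ccc2[nH]c(-c3ccc(OCCC4CCCCN4Cc4ccc(Cl)c(Cl)c4)cc3)nc2c1` gives 229000 nM as the only numbers. Compound 3 `CC(=O)N1CCCC(COc2ccc(-c3nc4cc(C(N)=O)ccc4[nH]3)cc2)C1` stands nowhere on this scale: its entry reads "not determined" (no result reported) and offers no baseline. The change to compound 4 `CC(=O)N1CCCCC1CCOc1ccc(-c2nc3cc(C(N)=O)ccc3[nH]2)cc1` is (1-acetylpiperidin-2-yl)methyl in place of 1-acetylpiperidin-3-yl on a saturated chain carbon bound to an oxygen on an aromatic ring and amounts to (1-acetylpiperidin-2-yl)methyl in place of 1-acetylpiperidin-3-yl on a saturated chain carbon bound to an oxygen on an aromatic ring.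

Among the compounds with values here, the single measured step, a 1.5-fold higher number from compound 1 to compound 2 (0.17 log units; within the scatter), stays within the scatter and concerns a different place, the phenyl on a saturated chain carbon bound to an amine nitrogen in a ring. Within the data shown here, no measured step covers the present exchange, and without a value for compound 3 no step size or direction in this assay can be expected from it. The estimate therefore rests only on the range set by compound 1 at 155000 nM and compound 2 at 229000 nM and stays wide, since neither carries the acetyl group. Compound 4 is expected at 150000 nM with an estimated range of 40000 nM to 400000 nM in this measurement.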

Compound 4, solubility: 193000 nM
Beside the measured number, compound 4's estimate is 1.3-fold (0.11 log units) below it; low and high end bracket the measured number.
By their numbers in this assay, from the lowest: compounds 1, 4 and 2 (each within the scatter of the next).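

In this assay, acetyl in place of 3,4-dichlorobenzyl on an amine nitrogen in a ring gives a 1.2-fold lower number from compound 2 to compound 4 (0.07 log units; within the scatter), and acetyl in place of benzyl at that nitrogen gives a 1.2-fold higher number from compound 1 to compound 4 (0.10 log units; within the scatter). The earlier step changed only the aromatic ring of the benzyl group, whereas these two steps exchange the whole substituent on the nitrogen, and compounds 1, 2 and 4 all remain within the scatter of one another. The exchange from compound 3 to compound 4 cannot be read, as compound 3 has no result, and no supporting evidence bears on these numbers.

Going by these compounds, whether a carboxylic acid or a sulfonamide on that nitrogen would also stay within the scatter remains open. The shown compounds also leave open how a longer chain on the oxygen would read in this assay.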